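The source may report more compounds than this note shows. Statements on the series, on what has been measured and on what is new or still open speak of the compounds shown alone.

Measured in a functional assay on K562 cells (Homo sapiens) for antiproliferative activity, read by MTT assay, with a stated time of 48 h; a higher number here means a weaker inhibitor, a lower number a stronger inhibitor:
- Compound 1 `CN(C)CCn1c(N)c(-c2nc3ccccc3[nH]2)c2nc(C#N)c(C#N)nc21`: 6340 nM
- Compound 2 `CN(C)CCn1c(N)c(-c2nc3ccccc3n2C)c2nc(C#N)c(C#N)nc21`: > 50000 nM

For compound 2, > 50000 nM is a limit of the assay and not a number. Compound 3 `CN(C)CCCCn1c(N)c(-c2nc3ccccc3n2C)c2nc(C#N)c(C#N)nc21` keeps the methyl of compound 2 but carries a longer side chain: 2-(dimethylamino)ethyl in place of dimethylamino on a saturated chain carbon, two bonds along the chain from an aromatic nitrogen. Within the data shown here, the only measured step, an at least 7.8-fold higher number from compound 1 to compound 2 (0.89 log units; beyond the scatter), is methyl in place of hydrogen on an aromatic nitrogen, a different change, so it gives no direct size for this one. A small move towards a lower number in this assay is expected, or none that can be read. For compound 3 the estimate is 35000 nM, with an expected range of 10000 nM to 60000 nM. This estimate means an expected at least 1.4-fold lower number from compound 2 to compound 3 (0.15 log units; that floor lies within the scatter).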

Compound 3, half-maximal inhibitory concentration: 1450 nM
Estimate against measurement, compound 3: 24-fold (1.38 log units) above, outside the stated range (below it).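

Where the earlier pair spoke only to the methyl, this result shows that the side chain counts as well: going from 2-(dimethylamino)ethyl to 4-(dimethylamino)butyl in this assay gives an at least 34-fold lower number from compound 2 to compound 3 (1.53 log units; beyond the scatter). The methyl on the aromatic nitrogen therefore does not by itself rule out activity. For compound 2, > 50000 nM is a limit of the assay and not a number, so the true size of this step stays open because of it: the limit of > 50000 nM in this assay, at which 1 of the 3 values shown sits.

Still open, as far as these compounds go, is how 3-(dimethylamino)propyl or a longer chain would read here. Also open, from the compounds shown here alone, is what hydrogen in place of the methyl would give on the 4-(dimethylamino)butyl chain.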